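Compound 3 to compound 4: a dioxolane on the chain

The source may report more compounds than this note shows. Statements on the series, on what has been measured and on what is new or still open speak of the compounds shown alone.

In a functional assay on SGC-7901 cells (Homo sapiens) for antiproliferative activity, read by sulforhodamine B assay, with a stated time of 72 h (a lower number here means a stronger inhibitor, a higher number a weaker inhibitor), compound 1 `CC(=O)Oc1cc2c(CCC=C(C)C)c(C)ccc2cc1C(C)C` gives 34400 nM and compound 2 `CC(=O)Oc1cc2c(CC[C@H](O)C(C)(C)O)c(C)ccc2cc1C(C)C` gives 45800 nM while compound 3 `CC(=O)Oc1cc2c(CC[C@@H](O)C(C)(C)O)c(C)ccc2cc1C(C)C` gives 47500 nM as its value. All three lie within the scatter of one another, so compound 3 holds no separate rank in this small set. Among the compounds with values here, compound 4 `CC(=O)Oc1cc2c(CC[C@@H]3OC(C)(C)OC3(C)C)c(C)ccc2cc1C(C)C` is reached from compound 3 through 2,2,5,5-tetramethyl-1,3-dioxolan-4-yl in place of 1,2-dihydroxy-2-methylpropyl on a saturated chain carbon, two bonds along the chain from an aromatic carbon as the single change, with 2,2,5,5-tetramethyl-1,3-dioxolan-4-yl in place of 1,2-dihydroxy-2-methylpropyl. Replacing 2-methylprop-1-en-1-yl at the same place gave a 1.3-fold higher number from compound 1 to compound 2 (0.12 log units; within the scatter) and also a 1.4-fold higher number from compound 1 to compound 3 (0.14 log units; within the scatter) in the two stereoisomers. Inverting the stereocentre gave a 1.0-fold higher number from compound 2 to compound 3 (0.02 log units; within the scatter) as the result. Within the data shown here, no measured compound carries the new ring, so the evidence is indirect. Since neither kind of step left the scatter, no step beyond the scatter is expected in this assay here. The estimated step is a 1.2-fold lower number from compound 3 to compound 4 (0.07 log units; within the scatter) with no firm direction. For compound 4 the expected value is 40000 nM with an estimated range of 20000 nM to 80000 nM in this read-out.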

Compound 4, half-maximal inhibitory concentration: 88900 nM
Estimate against measurement, compound 4: 2.2-fold (0.35 log units) below; the whole stated range lies below it.
By their numbers in this assay, from the lowest: compounds 1, 2, 3 and 4 (each within the scatter of the next, the first and the last beyond it).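

In this assay, 2,2,5,5-tetramethyl-1,3-dioxolan-4-yl in place of 1,2-dihydroxy-2-methylpropyl gives a 1.9-fold higher number from compound 3 to compound 4 (0.27 log units; within the scatter) and a 1.9-fold higher number from compound 2 to compound 4 (0.29 log units; within the scatter), so the new ring does not separate from either diol. Against the 2-methylprop-1-en-1-yl chain end, the same ring gives a 2.6-fold higher number from compound 1 to compound 4 (0.41 log units; beyond the scatter), the first step at this position to leave the scatter, which places compound 4 as a modestly weaker inhibitor than compound 1. Nothing given here accounts for that step.

On these data alone, whether an amine or a carboxylic acid at this saturated chain carbon, or a longer chain, would move the number in either direction stays open. As far as these compounds go, the effect of inverting the stereocentre of the new ring also stays open.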